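The source may hold more compounds than are shown below. What is called first, only, known or untested is meant among the compounds shown, and "the series" means these compounds.

Compound 1 `CCCOc1ccc(C[C@@H](Cc2ccccc2)C(=O)O)cc1CNC(=O)c1ccc(-c2cccc(F)c2)cc1` is the starting point. In a physicochemical assay for solubility, read by HPLC, in phosphate buffer, measured as thermodynamic solubility, with a stated time of 48 h, at pH 7.2 (on this read-out lower numbers stand for lower solubility and higher numbers for higher solubility), compound 1 gives < 1 ug/mL, which is a limit of the assay rather than a number (the limit of < 1 ug/mL in this assay, at which 1 of the 2 values shown sits). Compound 2 `CCCOc1ccc(C[C@@H](Cc2ccccc2)C(=O)O)cc1CNC(=O)c1ccc(-c2cncnc2)cc1` gives 190 ug/mL in this assay, a step of an at least 190-fold higher number from compound 1 to compound 2 (2.27 log units; beyond the scatter). Compound 3 `CCCOc1ccc(C[C@@H](Cc2ccccc2)C(=O)O)cc1CNC(=O)c1ccc(-c2ccccn2)cc1` is not yet measured; it differs from compound 1 by pyridin-2-yl in place of 3-fluorophenyl on an aromatic carbon. The step of an at least 190-fold higher number from compound 1 to compound 2 (2.27 log units; beyond the scatter) bears on this change, as it too exchanges the 3-fluorophenyl for a six-membered aromatic ring with a hetero atom, so a rise in this assay is expected, though of uncertain size. Compound 3 is therefore estimated at 20 ug/mL, between 3 ug/mL and 90 ug/mL, an expected step of an at least 20-fold higher number from compound 1 to compound 3 (1.30 log units; beyond the scatter).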

Compound 3, solubility: 17 ug/mL
Compound 3: the middle estimate sits 1.2-fold (0.07 log units) above what was measured, within the range that was stated.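

In this assay, pyridin-2-yl in place of 3-fluorophenyl also goes with a large rise, an at least 17-fold higher number from compound 1 to compound 3 (1.23 log units; beyond the scatter), so the rise at this position is not confined to pyrimidin-5-yl. The two rings with hetero atoms still differ clearly, with an 11-fold lower number from compound 2 to compound 3 (1.05 log units; beyond the scatter). The value of compound 1 is a limit of the assay and not a number: the limit of < 1 ug/mL in this assay, at which 1 of the 3 values shown sits.

The compounds shown cannot separate the count of ring nitrogen atoms from their place in the ring. From the compounds shown here alone, how a pyridin-4-yl ring or a morpholine would read also remains open.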